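The source may report more compounds than this note shows. Statements on the series, on what has been measured and on what is new or still open speak of the compounds shown alone.

Compound 1 `O=C(NCCNc1nccc(-c2c(-c3cccc(F)c3)nc3sccn23)n1)c1ccccc1`: in an ADME assay on L132 cells (Homo sapiens) for cytotoxicity, read by MTT assay (on this read-out lower numbers stand for stronger inhibition and higher numbers for weaker inhibition), compound 1 gives 200000 nM. Compound 2 `O=S(=O)(NCCCNc1nccc(-c2c(-c3cccc(F)c3)nc3sccn23)n1)c1ccccc1`: in this assay compound 2 gives > 400000 nM, which is a limit of the assay and not a number.

Compound 2 therefore sits at the limit, the position of one of the two values shown (the limit of > 400000 nM in this assay, at which 1 of the 2 values shown sits). Compound 3 `Cc1ccc(C(=O)NCCNc2nccc(-c3c(-c4cccc(F)c4)nc4sccn34)n2)cc1` differs from it thus: ((4-methylphenyl)carbonyl)amino in place of ((phenylsulfonyl)amino)methyl on a saturated chain carbon, two bonds along the chain from a nitrogen on an aromatic ring. Within the data shown here, the one measured step that bears on this change is an at least 2.0-fold higher number from compound 1 to compound 2 (0.30 log units; that floor lies within the scatter), and its floor lies within the scatter. On that basis compound 3 is expected to move back toward compound 1, with the step of an at least 2.0-fold higher number from compound 1 to compound 2 (0.30 log units; that floor lies within the scatter) giving only a weak pointer. Compound 3 is estimated at 250000 nM, within 100000 nM to 500000 nM. The expected step is an at least 1.6-fold lower number from compound 2 to compound 3 (0.20 log units; that floor lies within the scatter).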

Compound 3, half-maximal inhibitory concentration: 245000 nM
The estimate for compound 3 lay 1.0-fold (0.01 log units) above the measured number, within the range that was stated.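

In this assay, among these compounds, the step of a 1.2-fold higher number from compound 1 to compound 3 (0.09 log units; within the scatter) shows that methyl in place of hydrogen on an aromatic carbon leaves the read-out within the scatter, a comparison the earlier compounds did not offer. Compound 2 gives > 400000 nM, which is a limit of the assay and not a number. The step of an at least 1.6-fold lower number from compound 2 to compound 3 (0.21 log units; that floor lies within the scatter) is therefore only a floor, and that floor stays within the scatter. Still open, from the compounds shown here alone, is whether an amine or a carboxylic acid in place of that methyl, or a longer chain carrying the amide, would change the read-out.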